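Shrinking the Ring on the Amide Nitrogen

The source may hold more compounds than are shown below. What is called first, only, known or untested is meant among the compounds shown, and "the series" means these compounds.

Compound 1, `C#CCn1cc(C(=O)NC(CC(=O)Nc2ccccc2)c2ccccc2)c(=O)c2cc(F)c(Cl)nc21`, gives 6900 nM in a functional assay on MIA PaCa-2 cells (Homo sapiens) for cytotoxicity, read by MTT assay, with a stated time of 72 h; a higher number here means a weaker inhibitor, a lower number a stronger inhibitor.
Compound 2, `C#CCn1cc(C(=O)NC(CC(=O)NC2CCCCC2)c2ccccc2)c(=O)c2cc(F)c(Cl)nc21`, gives 4900 nM in this assay.
Compound 3, `C#CCn1cc(C(=O)NC(CC(=O)Nc2ccccc2)c2ccccc2)c(=O)c2cccnc21`, gives only a limit of the assay in this assay, > 10000 nM.

Among the two numbers measured, compound 2 has the lowest; its nearest neighbour is compound 1, and the step of a 1.4-fold lower number from compound 1 to compound 2 (0.15 log units; within the scatter) lies within the scatter. Compound 3 carries a limit, not a number, and so cannot be placed against them.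

Compound 4, `C#CCn1cc(C(=O)NC(CC(=O)NC2CCCC2)c2ccccc2)c(=O)c2cc(F)c(Cl)nc21`, is the next variation on compound 2: cyclopentyl in place of cyclohexyl on an amide-type nitrogen. Among the compounds with values here, the only measured step at this nitrogen is the one from compound 1 to compound 2, which swapped phenyl for cyclohexyl and stayed within the scatter. Within the data shown here, no measured step changes the size of a saturated ring here, so there is no evidence to expect a move in either direction beyond the scatter in this assay.

Compound 4 is therefore expected to give about 5000 nM, within a range from 2500 nM to 10000 nM, a step of a 1.0-fold higher number from compound 2 to compound 4 (0.01 log units; within the scatter).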

Compound 4, half-maximal inhibitory concentration: 4400 nM
Beside the measured number, compound 4's estimate is 1.1-fold (0.06 log units) above it; measured number inside the range.
By their numbers in this assay, from the lowest: compounds 4, 2 and 1 (each within the scatter of the next). At a limit, above all of these: compound 3.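

In this assay the step for cyclopentyl in place of cyclohexyl is a 1.1-fold lower number from compound 2 to compound 4 (0.05 log units; within the scatter) and the step for cyclopentyl in place of phenyl is a 1.6-fold lower number from compound 1 to compound 4 (0.20 log units; within the scatter) on the same amide-type nitrogen. Together with the earlier step, this places the phenyl, cyclohexyl and cyclopentyl compounds within the scatter of one another, so neither of these two saturated ring sizes separates from phenyl here. Nothing measured among the data shown explains why these three rings read alike.

The compounds shown leave open whether a group of another kind on this nitrogen, such as a ring carrying an amine or a carboxylic acid, or a longer open chain, would move the number beyond the scatter. A smaller carbon ring, such as cyclopropyl, also remains an open case.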